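This account rests on a few compounds, and the source may have more. Where it says the series, first, only, none or still open, it means among the compounds named here.

Measured in a functional assay on MCF7 cells (Homo sapiens) for cytotoxicity, read by MTT assay, with a stated time of 72 h; a lower number here means a stronger inhibitor, a higher number a weaker inhibitor:

- Compound 1 `Cn1ccc2c(Oc3ccc(NC(=O)c4cc5cccnc5n(-c5ccccc5)c4=O)cc3F)ncnc21`: 73400 nM
- Compound 2 `Cn1ccc2c(Oc3ccc(NC(=O)c4cc5cccnc5n(-c5ccc(F)cc5)c4=O)cc3F)ncnc21`: 11900 nM
- Compound 3 `O=C(Nc1ccc(Oc2ncnc3[nH]ccc23)c(F)c1)c1cc2cccnc2n(-c2ccccc2)c1=O`: 45000 nM

Compound 3, at 45000 nM, sits within the scatter of compound 1, with a 1.6-fold lower number from compound 1 to compound 3 (0.21 log units; within the scatter). Together these two hold the high end of the three numbers, while compound 2 shows the lower value of 11900 nM.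

Compound 4 `O=C(Nc1ccc(Oc2ncnc3[nH]ccc23)c(F)c1)c1cc2cccnc2n(-c2ccc(F)cc2)c1=O` departs from compound 3 by fluoro in place of hydrogen on an aromatic carbon, which is fluoro in place of hydrogen on an aromatic carbon, turning phenyl into 4-fluorophenyl. The same replacement has been measured once, in the pair of compound 1 and compound 2, as a 6.2-fold lower number from compound 1 to compound 2 (0.79 log units; beyond the scatter), a modest step beyond the scatter. The step of a 1.6-fold lower number from compound 1 to compound 3 (0.21 log units; within the scatter) shows no separation between the methyl and hydrogen forms, so that precedent plausibly carries over. With a single precedent, a step in the same direction but somewhat smaller is expected in this assay. The expected change is a 3.2-fold lower number from compound 3 to compound 4 (0.51 log units; beyond the scatter). For compound 4 the estimated value is 14000 nM. The expected range for compound 4 runs from 5000 nM to 40000 nM.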

Compound 4, half-maximal inhibitory concentration: 9230 nM
Estimate against measurement, compound 4: 1.5-fold (0.18 log units) above, and the stated range covers the measured number.
By their numbers in this assay, from the lowest: compounds 4 and 2 (each within the scatter of the next); then compounds 3 and 1 (each within the scatter of the next).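

In this assay, the change from phenyl to 4-fluorophenyl now appears on a second core, with a 4.9-fold lower number from compound 3 to compound 4 (0.69 log units; beyond the scatter), and the earlier step no longer stands alone, since the two agree in size: the same change on two cores in this assay, a 6.2-fold lower number (0.79 log units; beyond the scatter) from compound 1 to compound 2 and a 4.9-fold lower number (0.69 log units; beyond the scatter) from compound 3 to compound 4, 1.3-fold (0.10 log units) apart, within the scatter of two such steps. Hydrogen in place of methyl on the aromatic nitrogen again separates nothing when the 4-fluorophenyl group is present, with a 1.3-fold lower number from compound 2 to compound 4 (0.11 log units; within the scatter), which matches the step seen with phenyl: the same change on two cores in this assay, a 1.6-fold lower number (0.21 log units; within the scatter) from compound 1 to compound 3 and a 1.3-fold lower number (0.11 log units; within the scatter) from compound 2 to compound 4, 1.3-fold (0.10 log units) apart, within the scatter of two such steps. Across these four compounds, the fluoro step therefore holds with either methyl or hydrogen on that nitrogen.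

Only hydrogen and fluoro appear at this position among the compounds shown, so how a chloro, a methoxy or an amine there would read in this assay remains open.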